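The compounds below may be only part of what the source reports. "The series", "measured", "known", "first", "only" and "open" are said of these compounds alone.

Compound 1 `Cc1noc(C)c1-c1cnc(N)c(Oc2ccc(C(=O)NC3CCCC3)cc2)n1`: 25200 nM
Compound 2 `Cc1noc(C)c1-c1cnc(N)c(Oc2ccc(C(=O)NC3CCCCC3)cc2)n1`: 21600 nM
Compound 3 `Cc1noc(C)c1-c1cnc(N)c(Oc2ccc(C(=O)Nc3ccccc3Cl)cc2)n1`: > 100000 nM

In a functional assay on LoVo cells (Homo sapiens) for inhibition, read by MTT assay, with a stated time of 72 h (on this read-out higher numbers stand for weaker inhibition and lower numbers for stronger inhibition), compound 3 gives no number, only the limit > 100000 nM. Among the three measured compounds it stands weakest: an at least 3.9-fold higher number from compound 1 to compound 3 (0.59 log units; beyond the scatter) and an at least 4.6-fold higher number from compound 2 to compound 3 (0.66 log units; beyond the scatter), whereas a 1.2-fold lower number from compound 1 to compound 2 (0.07 log units; within the scatter). Compound 4 `Cc1noc(C)c1-c1cnc(N)c(Oc2ccc(C(=O)Nc3ccc(Cl)cc3)cc2)n1` has not yet been measured in this assay; its change from compound 3 is 4-chlorophenyl in place of 2-chlorophenyl on an amide-type nitrogen. Among the measured compounds shown here, no measured step compares two chlorophenyl groups with each other, so the expectation for compound 4 rests only on compound 3 sitting at the limit of > 100000 nM in this assay, at which 1 of the 3 values shown sits. Compound 4 is therefore expected to remain in the same weak region, with a step of about an at least 1.1-fold lower number from compound 3 to compound 4 (0.04 log units; that floor lies within the scatter). Compound 4 is estimated at 90000 nM, within a range from 25000 nM to 300000 nM.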

Compound 4, half-maximal inhibitory concentration: 1920 nM
The estimate for compound 4 lay 47-fold (1.67 log units) above the measured number, outside the stated range (below it).
By their numbers in this assay, from the lowest: compound 4; then compounds 2 and 1 (each within the scatter of the next). At a limit, above all of these: compound 3.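

In this assay, the same atoms joined differently separate two very different results: 4-chlorophenyl in place of 2-chlorophenyl on the amide-type nitrogen gives an at least 52-fold lower number from compound 3 to compound 4 (1.71 log units; beyond the scatter). This step is a floor, since compound 3 has only a limit: the limit of > 100000 nM in this assay, at which 1 of the 4 values shown sits. The earlier compounds shown here showed a chlorophenyl group only as the poorer choice, yet here the 4-chlorophenyl group outdoes both cycloalkyl groups, with an 11-fold lower number from compound 2 to compound 4 (1.05 log units; beyond the scatter) and a 13-fold lower number from compound 1 to compound 4 (1.12 log units; beyond the scatter), and compound 3 goes against this.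

The compounds shown leave open how 3-chlorophenyl would behave on this nitrogen. They also leave open whether chlorine is needed at all, as they include neither plain phenyl nor 4-methoxyphenyl.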